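This account rests on a few compounds, and the source may have more. Where it says the series, first, only, none or still open, it means among the compounds named here.

In a functional assay on U-251 cells (Homo sapiens) for antiproliferative activity, read by MTT assay, with a stated time of 48 h (on this read-out lower numbers stand for stronger inhibition and higher numbers for weaker inhibition), two compounds sharing one core have been measured so far. Compound 1 `COc1cc(-c2cccc3nc(-c4ccc(C)cc4)oc23)cc(OC)c1OC` gives 3200 nM. Compound 2 `COc1cc(-c2nc3cccc(-c4cc(OC)c(OC)c(OC)c4)c3o2)ccc1O` gives 10300 nM, the higher of the two numbers and so the weaker inhibition.

Compound 3 `COc1cc(-c2cccc3nc(-c4ccc(N)cc4)oc23)cc(OC)c1OC` keeps the same core and differs from compound 2 by one group: 4-aminophenyl in place of 4-hydroxy-3-methoxyphenyl on an aromatic carbon. It carries 4-aminophenyl in place of 4-hydroxy-3-methoxyphenyl, on an aromatic carbon of a five-membered aromatic ring with 1 nitrogen and 1 oxygen.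

Going by the values given here, only one measured step touches this place, a 3.2-fold higher number from compound 1 to compound 2 (0.51 log units; beyond the scatter). That step is modest but beyond the usual scatter, and it shows that the group here can move the number. Among the compounds with values here, it is a single step, though, and no measured compound yet carries 4-aminophenyl, so the guidance is thin. Leaving 4-hydroxy-3-methoxyphenyl is expected to give back much of that modest step, toward compound 1 at 3200 nM, so a lower number is expected in this assay.

The expected change is a 2.3-fold lower number from compound 2 to compound 3 (0.36 log units; beyond the scatter). For compound 3 the estimated value is 4500 nM, with an expected range from 1500 nM to 13000 nM.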

Compound 3, half-maximal inhibitory concentration: 1040 nM
Compound 3: middle estimate off by 4.3-fold (0.64 log units), on the high side, and the stated range ends above it.
By their numbers in this assay, from the lowest: compound 3; then compound 1; then compound 2.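

The position is more than a switch between a weaker and a less weak compound: 4-aminophenyl does not merely return to the level of compound 1 but goes past it, giving a 9.9-fold lower number from compound 2 to compound 3 (1.00 log units; beyond the scatter) in this assay. Going by these compounds alone, the comparison with the 4-methylphenyl compound is the tighter one, since only one small group on that phenyl ring changes, and amino in place of methyl gives a 3.1-fold lower number from compound 1 to compound 3 (0.49 log units; beyond the scatter), so this single swap on an aromatic carbon is enough to move the number beyond the usual scatter and makes compound 3 the strongest inhibitor of the three. Nothing given here explains why the amino group goes with the lowest number in this series.

Still open, on these data alone, is whether this gain is specific to a free amino group or would also appear with a close relative in its place, such as a dimethylamino group, an acetamide or a simple hydroxyl. Also open, as far as these compounds go, is how a carboxylic acid or a longer chain on that phenyl ring would behave, and whether the hydroxyl or the methoxy of compound 2 accounts for its higher number.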